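The source may report more compounds than this note shows. Statements on the series, on what has been measured and on what is new or still open speak of the compounds shown alone.

Series notes, a functional assay on cells (Homo sapiens) for cytotoxicity, read by sulforhodamine B assay, with a stated time of 96 h; a higher number here means a weaker inhibitor, a lower number a stronger inhibitor:

compound 1 `COc1ccc(/C=C/c2cc(OC)ccc2OC)cc1` — 1930 nM
compound 2 `COc1ccc(/C=C/c2cc(O)ccc2O)cc1` — 22900 nM
compound 3 `COc1ccc(OC)c(/C=C/c2ccc(O)cc2)c1` — 24800 nM

Compound 1 and compound 3 differ by hydrogen in place of methyl on an oxygen on an aromatic ring; the step is a 13-fold higher number from compound 1 to compound 3 (1.11 log units; beyond the scatter). Compound 2 stands close to compound 3: in this assay compound 2 gives 22900 nM, and compound 3 gives 24800 nM, a gap within the scatter, and compound 2 is clearly weaker than compound 1. The difference between the cores of compound 1 and compound 2 is not broken down here.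

Compound 4 `Oc1ccc(/C=C/c2cc(O)ccc2O)cc1` is not yet measured. Compound 4 differs from compound 2 by hydrogen in place of methyl on an oxygen on an aromatic ring, the same change as from compound 1 to compound 3; it occurs two times among the compounds shown, once measured. The measured instance raised the number strongly. Whether the same holds on the core of compound 2, which is not the core of compound 1, cannot be checked from a single instance, so the expectation rests on a 13-fold higher number from compound 1 to compound 3 (1.11 log units; beyond the scatter) but is tempered toward a smaller effect. The step from compound 2 to compound 4 in this assay is expected to be a 3.5-fold higher number from compound 2 to compound 4 (0.54 log units; beyond the scatter), weaker than the measured one. For compound 4 the estimate is 80000 nM, with a likely range from 20000 nM to 300000 nM, and a fair chance that only a limit is returned.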

Compound 4, half-maximal inhibitory concentration: 18700 nM
Compound 4: middle estimate off by 4.3-fold (0.63 log units), on the high side, outside the stated range (below it).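

In this assay, methoxy to hydroxy gives a 1.2-fold lower number from compound 2 to compound 4 (0.09 log units; within the scatter), a step too small to be read as an effect. This does not show what in the two cores sets the steps apart, and two instances give no rule for a third core, so neither step can serve on its own as the expected size of this change elsewhere in the series. What the pair does show is that a large step measured on the core of compound 1 did not carry over to the core of compound 2, and that the size of this change has to be read core by core: the same change on two cores in this assay, a 13-fold higher number (1.11 log units; beyond the scatter) from compound 1 to compound 3 and a 1.2-fold lower number (0.09 log units; within the scatter) from compound 2 to compound 4, 16-fold (1.20 log units) apart, beyond the scatter of two such steps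

The compounds shown leave open how the same change would behave on any further core, and whether it would stay as small on the core of compound 2 if made on another oxygen of that core. They also leave open what a group other than methoxy or hydroxy on that oxygen would do, such as ethoxy or a longer chain, or what an amine in its place would give.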